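A few compounds are considered here, and "the series" means these few. Any claim that something is new, unique, unknown or untested is made for them only; others in the source may bear on it.

Compound 1, `CCOC(=O)c1cnn(-c2nc(-c3ccccc3O)c(C#N)c(=O)n2C)c1N`, and compound 3, `CCOC(=O)c1cnn(-c2nc(-c3ccccc3Cl)c(C#N)c(=O)n2C)c1N`, share one core and differ in a single place: chloro in place of hydroxy on an aromatic carbon. In a functional assay, with a stated time of 10 min (a lower number here means a stronger inhibitor, a higher number a weaker inhibitor), compound 1 gives 58 ug/mL, and compound 3 gives 98 ug/mL; the step between them is a 1.7-fold higher number from compound 1 to compound 3 (0.23 log units; within the scatter). Compound 2, `Cn1c(NN)nc(-c2ccccc2O)c(C#N)c1=O`, carries the same 2-hydroxyphenyl group on a different core; the difference between the two cores is not broken down here. In this assay compound 2 gives 30 ug/mL, which lies within the scatter of compound 1 and beyond the scatter of compound 3. Compound 4, `Cn1c(NN)nc(-c2ccccc2Cl)c(C#N)c1=O`, has not yet been measured. It differs from compound 2 by chloro in place of hydroxy on an aromatic carbon, the same change as between compound 1 and compound 3, made at the same kind of place. Given that the first instance of this change produced a step of a 1.7-fold higher number from compound 1 to compound 3 (0.23 log units; within the scatter), the step expected here is a 1.7-fold higher number from compound 2 to compound 4 (0.22 log units; within the scatter). Compound 4 is therefore estimated at 50 ug/mL, within a range from 25 ug/mL to 100 ug/mL.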

Compound 4, half-maximal inhibitory concentration: 46 ug/mL
Estimate against measurement, compound 4: 1.1-fold (0.04 log units) above; measured number inside the range.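

In this assay, chloro in place of hydroxy on the aromatic carbon gives a 1.5-fold higher number from compound 2 to compound 4 (0.19 log units; within the scatter), so the step on this second core is also small. Set beside the first instance of the change, the two steps agree, which means that in these four compounds the change carries over from one core to the other: the same change on two cores in this assay, a 1.7-fold higher number (0.23 log units; within the scatter) from compound 1 to compound 3 and a 1.5-fold higher number (0.19 log units; within the scatter) from compound 2 to compound 4, 1.1-fold (0.04 log units) apart, within the scatter of two such steps

This does not show that chloro and hydroxy truly differ on either core, as each step lies within the scatter, and two cores cannot say how the change would behave on a third.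

The compounds shown carry only hydroxy or chloro at this place, so it remains open how an amine, a methoxy group or a carboxylic acid there would read on these two cores. On these data alone, it is also open whether a step large enough to stand clear of the scatter would carry over between the cores as closely as these two small steps do.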